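The compounds below may be only part of what the source reports. "The series", "measured", "known", "first", "only" and "open" are said of these compounds alone.

Compound 1 `OC[C@H]1O[C@@H](n2cnc3c(NCc4ccc(Cl)cc4Cl)ncnc32)[C@H](O)[C@@H]1O` and compound 2 `OC[C@H]1O[C@@H](n2cnc3c(NCc4c(F)ccc(F)c4F)ncnc32)[C@H](O)[C@@H]1O` share one core and differ only in the aryl group on the saturated chain carbon bound to a nitrogen on an aromatic ring. In a functional assay on CCRF-CEM cells (Homo sapiens) for antiproliferative activity, with a stated time of 72 h (a higher number here means a weaker inhibitor, a lower number a stronger inhibitor), compound 1 gives 86700 nM, and in this assay compound 2 gives 90300 nM. The step of a 1.0-fold higher number from compound 1 to compound 2 (0.02 log units; within the scatter) shows that swapping one halogenated aryl group for another left the read-out essentially unchanged. Going by the values given here, compound 2 stands with the highest of the two numbers, but its only neighbour, compound 1, sits within the scatter, so no order can be drawn between them.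

Compound 3 `COc1cccc(CNc2ncnc3c2ncn3[C@@H]2O[C@H](CO)[C@@H](O)[C@H]2O)c1O` is the next step from compound 2, with the change (2-hydroxy-3-methoxyphenyl in place of 2,3,6-trifluorophenyl on a saturated chain carbon bound to a nitrogen on an aromatic ring). Among the compounds with values here, the only measured step that bears on it, from compound 1 to compound 2, altered the same aryl position and stayed within the scatter, so the expectation for this assay is a step of no more than the scatter, with no clear direction, as a 1.0-fold lower number from compound 2 to compound 3 (0.00 log units; within the scatter). The estimated value for compound 3 in this assay is therefore 90000 nM, within a range from 35000 nM to 230000 nM.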

Compound 3, half-maximal inhibitory concentration: 300 nM
Estimate against measurement, compound 3: 300-fold (2.48 log units) above; the whole stated range lies above it.
By their numbers in this assay, from the lowest: compound 3; then compounds 1 and 2 (each within the scatter of the next).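

In this assay, the aryl group on a saturated chain carbon bound to a nitrogen on an aromatic ring proves able to move the read-out strongly: the 2-hydroxy-3-methoxyphenyl group gives a 300-fold lower number from compound 2 to compound 3 (2.48 log units; beyond the scatter) and a 290-fold lower number from compound 1 to compound 3 (2.46 log units; beyond the scatter) while the exchange between the two halogenated aryl groups had stayed within the scatter. Among these three compounds, the two carrying 2,4-dichlorophenyl and 2,3,6-trifluorophenyl therefore sit together, and compound 3 stands apart from both with a group that brings oxygen instead of halogen and, unlike 2,3,6-trifluorophenyl, counts a hydrogen-bond donor and hydrogen-bond acceptors. Nothing available here accounts for the size of this step.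

The hydroxy and methoxy groups enter together in compound 3, so the compounds shown leave open whether 2-hydroxyphenyl or 3-methoxyphenyl alone would give a number near that of compound 3 or near those of compound 1 and compound 2. They also leave open how an aminophenyl or a carboxyphenyl group would read at this same place.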